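This account rests on a few compounds, and the source may have more. Where it says the series, first, only, none or still open, it means among the compounds named here.

Compound 1 `CC[C@@H]1/C=C(\C)C[C@H](C)C[C@H](OC)[C@H]2O[C@@](O)(C(=O)C(=O)N3CCCC[C@H]3C(=O)O[C@H](/C(C)=C/[C@@H]3CC[C@@H](Oc4ccccc4)[C@H](OC)C3)[C@H](C)[C@@H](O)CC1=O)[C@H](C)C[C@@H]2OC`: in a functional assay on cells for inhibition, with Murine T-cell line (Mus musculus) as the target (a lower number here means a stronger inhibitor, a higher number a weaker inhibitor), compound 1 gives 5.4 nM.
Compound 2 `CC[C@@H]1/C=C(\C)C[C@H](C)C[C@H](OC)[C@H]2O[C@@](O)(C(=O)C(=O)N3CCCC[C@H]3C(=O)O[C@H](/C(C)=C/[C@@H]3CC[C@@H](Oc4ccc(C)cc4)[C@H](OC)C3)[C@H](C)[C@@H](O)CC1=O)[C@H](C)C[C@@H]2OC`: compound 2 gives 2.7 nM.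
Compound 3 `CC[C@@H]1/C=C(\C)C[C@H](C)C[C@H](OC)[C@H]2O[C@@](O)(C(=O)C(=O)N3CCCC[C@H]3C(=O)O[C@H](/C(C)=C/[C@@H]3CC[C@@H](Oc4ccc(N(C)C)cc4)[C@H](OC)C3)[C@H](C)[C@@H](O)CC1=O)[C@H](C)C[C@@H]2OC`: compound 3 gives 1.1 nM.

Compound 3 has the lowest number of the three, and its gaps to the others are both beyond the scatter: a 4.9-fold lower number from compound 1 to compound 3 (0.69 log units; beyond the scatter) and a 2.5-fold lower number from compound 2 to compound 3 (0.39 log units; beyond the scatter), whereas a 2.0-fold lower number from compound 1 to compound 2 (0.30 log units; within the scatter) stays within it. Compound 4 `CC[C@@H]1/C=C(\C)C[C@H](C)C[C@H](OC)[C@H]2O[C@@](O)(C(=O)C(=O)N3CCCC[C@H]3C(=O)O[C@H](/C(C)=C/[C@@H]3CC[C@@H](Oc4ccc(OC)cc4)[C@H](OC)C3)[C@H](C)[C@@H](O)CC1=O)[C@H](C)C[C@@H]2OC` differs from compound 3 in one place: methoxy in place of dimethylamino on an aromatic carbon. Among the compounds with values here, no measured step involves methoxy, so the only guide is that dimethylamino gave the lowest number in both steps toward compound 3. Replacing it is therefore expected to move the number modestly upward, as a 2.3-fold higher number from compound 3 to compound 4 (0.36 log units; beyond the scatter). Compound 4 is expected to give 2.5 nM in this assay, with a range from 1 nM to 6 nM.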

Compound 4, half-maximal inhibitory concentration: 1.4 nM
Beside the measured number, compound 4's estimate is 1.8-fold (0.25 log units) above it, within the range that was stated.
By their numbers in this assay, from the lowest: compounds 3, 4, 2 and 1 (each within the scatter of the next, the first and the last beyond it).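

In this assay methoxy on this aromatic carbon, para to a large group, cannot be told apart from dimethylamino (a 1.3-fold higher number from compound 3 to compound 4 (0.10 log units; within the scatter)) or from methyl (a 1.9-fold lower number from compound 2 to compound 4 (0.29 log units; within the scatter)), yet it stands clearly apart from plain hydrogen (a 3.9-fold lower number from compound 1 to compound 4 (0.59 log units; beyond the scatter)). The nitrogen of dimethylamino is therefore not needed for a low number here, since compound 4 carries oxygen in its place and stays within the scatter of compound 3. No supporting data bear on the reason for this result. The compounds shown leave open how a carboxylic acid, a fluorine atom or a longer chain such as butoxy would behave on this carbon.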